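The source may report more compounds than this note shows. Statements on the series, on what has been measured and on what is new or still open speak of the compounds shown alone.

Two compounds built on a shared core, differing only in the aryl group on one nitrogen of a urea, have been measured in a functional assay on U-251 cells (Homo sapiens) for inhibition, read by sulforhodamine B assay, with a stated time of 48 h; on this read-out higher numbers stand for weaker inhibition and lower numbers for stronger inhibition. Compound 1 `COc1cc(Cl)cc(-c2nn(-c3cccc(NC(=O)Nc4cc(C(F)(F)F)cc(C(F)(F)F)c4)c3)cc2-c2ccncc2)c1` gives 320 nM in this assay. Compound 2 `COc1cc(Cl)cc(-c2nn(-c3cccc(NC(=O)Nc4ccc(Cl)c(Cl)c4)c3)cc2-c2ccncc2)c1` gives 1700 nM in this assay, the higher of the two numbers and so the weaker inhibitor, with the gap to compound 1 beyond the usual scatter. Compound 3 `COc1cc(Cl)cc(-c2nn(-c3cccc(NC(=O)Nc4cccc(C(F)(F)F)c4)c3)cc2-c2ccncc2)c1` has not yet been measured; it carries 3-(trifluoromethyl)phenyl in place of 3,4-dichlorophenyl on an amide-type nitrogen, so it keeps a single trifluoromethyl group where compound 1 carries two. Among the measured compounds shown here, no matching pair of measured compounds exists to draw on, so the expected step rests on these two values alone: a move toward a lower number, a 2.1-fold lower number from compound 2 to compound 3 (0.33 log units; beyond the scatter), likely beyond the scatter yet short of what compound 1 gives. Compound 3 is therefore expected to give about 800 nM in this assay, within a range from 300 nM to 2200 nM.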

Compound 3, half-maximal inhibitory concentration: 880 nM
Compound 3: the middle estimate sits 1.1-fold (0.04 log units) below what was measured; the measured number falls inside the stated range.
By their numbers in this assay, from the lowest: compound 1; then compounds 3 and 2 (each within the scatter of the next).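

In this assay, 3-(trifluoromethyl)phenyl in place of 3,4-dichlorophenyl on the amide-type nitrogen gives a 1.9-fold lower number from compound 2 to compound 3 (0.29 log units; within the scatter) and so does not separate these two aryl groups. Hydrogen in place of one trifluoromethyl on an aromatic carbon gives a 2.8-fold higher number from compound 1 to compound 3 (0.44 log units; beyond the scatter) and so shows that the second trifluoromethyl group makes a real difference, leaving compound 1 the strongest of the three. Nothing shown here explains why the second trifluoromethyl group matters.

Still open, on these data alone, is whether a nitrile or a dimethylamino group on this aryl ring would match a trifluoromethyl group or fall short of it. The compounds shown also leave open whether the same differences would hold with any change to the shared core.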